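Swapping the Isobutyl Arm for a Methylphenyl Ring

A few compounds are considered here, and "the series" means these few. Any claim that something is new, unique, unknown or untested is made for them only; others in the source may bear on it.

Compound 3 `CC(C)CCc1cnc(CCc2ccc(-c3ccccc3C(=O)O)cc2)[nH]1` gives the lowest number of the three measured compounds in an in vitro functional assay on cells for agonist activity at Bombesin receptor subtype-3 (Mus musculus), read by luminescence and calcium flux (a lower number here means that less compound is needed, a higher number that more compound is needed for the effect), at 10 nM. Its nearest neighbour is compound 2 `N#Cc1cccc(Cc2cnc(CCc3ccc(-c4ccccc4C(=O)O)cc3)[nH]2)c1`, which gives 20 nM, and the step of a 2.0-fold lower number from compound 2 to compound 3 (0.30 log units; within the scatter) lies within the scatter, so the two cannot be ordered. Compound 1 `O=C(O)c1ccccc1-c1ccc(CCc2ncc(Cc3ccc(Cl)cc3)[nH]2)cc1` gives 102 nM, and the step of a 10-fold lower number from compound 1 to compound 3 (1.01 log units; beyond the scatter) is the only one in this set that is large.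

Compound 4 `Cc1ccc(Cc2cnc(CCc3ccc(-c4ccccc4C(=O)O)cc3)[nH]2)cc1` differs from compound 3 in one place: 4-methylphenyl in place of isobutyl on a saturated chain carbon bound to an aromatic carbon. The measured steps that bear on this change all concern the same saturated chain carbon. The step of a 5.1-fold lower number from compound 1 to compound 2 (0.71 log units; beyond the scatter) and the step of a 10-fold lower number from compound 1 to compound 3 (1.01 log units; beyond the scatter) show that an aromatic ring at this position can cost potency relative to the isobutyl chain, with the 4-chlorophenyl case costing more than the 3-cyanophenyl case. The 4-methylphenyl group of compound 4 carries its substituent at the same position as the 4-chlorophenyl group of compound 1, so a step back toward that number is expected, in the direction of a higher value, estimated at a 4.5-fold higher number from compound 3 to compound 4 (0.65 log units; beyond the scatter). Compound 4 is therefore expected to give about 45 nM in this assay, with a range from 15 nM to 130 nM.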

Compound 4, half-maximal effective concentration: 162 nM
Compound 4: the middle estimate sits 3.6-fold (0.56 log units) below what was measured; measured number above the stated range.
By their numbers in this assay, from the lowest: compounds 3 and 2 (each within the scatter of the next); then compounds 1 and 4 (each within the scatter of the next).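

Exchanging isobutyl for 4-methylphenyl on this saturated chain carbon gives a 16-fold higher number from compound 3 to compound 4 (1.21 log units; beyond the scatter) in this assay and is a large step, so this ring is clearly not interchangeable with the isobutyl arm. Methyl in place of chloro on the ring gives a 1.6-fold higher number from compound 1 to compound 4 (0.20 log units; within the scatter) and lies within the scatter, so the 4-methylphenyl and 4-chlorophenyl groups cannot be told apart here, and the two compounds now form a pair of their own. The change from 3-cyanophenyl to 4-methylphenyl gives an 8.1-fold higher number from compound 2 to compound 4 (0.91 log units; beyond the scatter) and lies beyond the scatter, which shows that the presence of an aromatic ring alone does not set the number, since compound 2 keeps a ring and still cannot be ordered against compound 3.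

Nothing in the data gives a reason for these differences. From the compounds shown here alone, it remains open whether a plain phenyl ring, a 3-methylphenyl group or a 4-cyanophenyl group at this place would group with compound 2 or with compound 4, and how a longer alkyl chain or an amine would compare with isobutyl.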